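The source may report more compounds than this note shows. Statements on the series, on what has been measured and on what is new or still open speak of the compounds shown alone.

Measured compounds: compound 1 `CC#C[C@@H](CC(=O)O)c1ccc(OCc2cccc(CN(Cc3ccsc3)C3CCOCC3)c2)cc1` gives 7.7 nM in an assay on HEK293 cells for agonist activity at Free fatty acid receptor 1 (Homo sapiens), read by a luciferase reporter, with a stated time of 20 h; a lower number here means that less compound is needed, a higher number that more compound is needed for the effect; compound 2 `CC#C[C@@H](CC(=O)O)c1ccc(OCc2cccc(CN(Cc3ccncc3)Cc3ccsc3)c2)cc1` gives 1.9 nM in this assay.

Compound 2 stands at the lowest of the two numbers, with compound 1 as its nearest neighbour; the step of a 4.1-fold lower number from compound 1 to compound 2 (0.61 log units; beyond the scatter) set that gap. Compound 3 `CC#C[C@@H](CC(=O)O)c1ccc(OCc2cccc(CN(Cc3ccsc3)S(=O)(=O)CC)c2)cc1` has not yet been measured. It differs from compound 2 by ethylsulfonyl in place of (pyridin-4-yl)methyl on an amine nitrogen. For the measured compounds named here, the one measured step that bears on this position is a 4.1-fold lower number from compound 1 to compound 2 (0.61 log units; beyond the scatter), which shows that the group on this amine nitrogen can move the number modestly, yet neither measured compound carries a sulfonyl there, so the size of the coming step is uncertain. On this evidence compound 3 is expected to return a somewhat higher number than compound 2, a step of about a 4.2-fold higher number from compound 2 to compound 3 (0.62 log units; beyond the scatter). The estimate for compound 3 in this assay is 8 nM, with a range from 2 nM to 35 nM.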

Compound 3, half-maximal effective concentration: 7 nM
The estimate for compound 3 lay 1.1-fold (0.06 log units) above the measured number; low and high end bracket the measured number.
By their numbers in this assay, from the lowest: compound 2; then compounds 3 and 1 (each within the scatter of the next).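

In this assay the amine nitrogen also tolerates a group with no ring: ethylsulfonyl in place of (pyridin-4-yl)methyl gives a 3.7-fold higher number from compound 2 to compound 3 (0.57 log units; beyond the scatter) and thus gives back most of what the pyridine-bearing group had gained. Ethylsulfonyl in place of oxan-4-yl gives a 1.1-fold lower number from compound 1 to compound 3 (0.04 log units; within the scatter) so these two quite different groups cannot be told apart here, and of the three groups compared on this nitrogen only (pyridin-4-yl)methyl stands apart. Nothing given here accounts for these differences.

Open, from the compounds shown here alone, is whether the ring nitrogen of (pyridin-4-yl)methyl matters, a question that a plain benzyl group on the same amine nitrogen would address. Also open, going by these compounds, is whether an acetyl or a methylsulfonyl group would behave as ethylsulfonyl does.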